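This account rests on a few compounds, and the source may have more. Where it says the series, first, only, none or still open, it means among the compounds named here.

Among the measured compounds shown here, compound 2 `O=C(O)CCCc1ccc(NCc2cccc(Oc3ccccc3)c2)cc1` is the one compound of the series with a number in a functional assay on CHO cells for agonist activity at Free fatty acid receptor 1 (Homo sapiens) (on this read-out higher numbers stand for an effect only at larger amounts of compound and lower numbers for an effect already at smaller amounts), where compound 2 gives 1120 nM. Compound 1 `O=C(O)c1ccc(NCc2cccc(Oc3ccccc3)c2)cc1` gives only a limit of the assay in this assay, < 10000 nM. The step that the limit leaves unreadable from compound 1 to compound 2 is therefore of unreadable size; the limit of < 10000 nM in this assay, at which 1 of the 2 values shown sits, records that limit. Compound 3 `O=C(O)/C=C/c1ccc(NCc2cccc(Oc3ccccc3)c2)cc1` differs from compound 2 in one place: 2-carboxyethenyl in place of 3-carboxypropyl on an aromatic carbon. For the measured compounds named here, no measured step bears on this change in a readable way, since the single measured step cannot be sized. The expectation for compound 3 is therefore set near compound 2, with a wide range in both directions, and the expected step of a 1.2-fold higher number from compound 2 to compound 3 (0.06 log units; within the scatter) is taken as within the scatter. Compound 3 is estimated at 1300 nM in this assay, expected to lie between 300 nM and 6000 nM.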

Compound 3, half-maximal effective concentration: 145 nM
Estimate against measurement, compound 3: 9.0-fold (0.95 log units) above; measured number outside the range, below it.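

In this assay the exchange of 3-carboxypropyl for 2-carboxyethenyl on an aromatic carbon para to a large group gives a 7.7-fold lower number from compound 2 to compound 3 (0.89 log units; beyond the scatter) and shows that the number at this position depends on the make-up of the chain, not only on the presence of its terminal carboxyl group. The two groups match in hydrogen-bond donors, hydrogen-bond acceptors and net charge, and differ in heavy atoms and in double bonds outside aromatic rings. Compound 1 has only a limit of the assay, and the steps from it cannot be read: the limit of < 10000 nM in this assay, at which 1 of the 3 values shown sits.

The compounds shown leave open whether the lower number follows the shorter chain or the double bond, which a 2-carboxyethyl group at the same place would separate. Also open, from the compounds shown here alone, is how a primary amide in place of the carboxylic acid would read.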